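A few compounds are considered here, and "the series" means these few. Any claim that something is new, unique, unknown or untested is made for them only; others in the source may bear on it.

Measured compounds and their results:

Compound 1 `CCN(CC)C(=O)CC1CCc2cc(OC)c(OC)cc21`: 40%
Compound 2 `COc1cc2c(cc1OC)C(CC(=O)NC(C)C)CC2`: 37%
Compound 3 `COc1cc2c(cc1OC)C(CC(=O)NCc1ccccc1)CC2`: 24%

In a functional assay on the whole organism (strain Wistar) for inhibition, with Rattus norvegicus as the target, read by paw edema, with stated times of 60 min and 2 h, at a dose of 100 mg/kg by the oral route (a higher number here means more inhibition at the dose given (going by the name of the read-out), a lower number less inhibition), compound 1 gives 40%, the highest of the three numbers. Compound 2 comes nearest, and the step of a number 3 percentage points lower from compound 1 to compound 2 (within the scatter) shows that swapping one amine for another on the carbonyl carbon left the result within the scatter. Compound 3 lies furthest away: the step of a number 16 percentage points lower from compound 1 to compound 3 (beyond the scatter) is a modest loss, and the related step of a number 13 percentage points lower from compound 2 to compound 3 (beyond the scatter) points the same way.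

Compound 4 `COc1cc2c(cc1OC)C(CC(=O)N1CCNCC1)CC2` has not yet been tested. It differs from compound 1 in one place: piperazin-1-yl in place of diethylamino on a carbonyl carbon. Both steps from compound 1 bear on this change, since each also exchanged the amine on the carbonyl carbon; one stayed within the scatter, the other was a modest loss. A ring amine is a new kind of change here, so the expectation is a small decrease, with the step of a number 7 percentage points lower from compound 1 to compound 4 (within the scatter) expected and possibly not beyond the scatter. For compound 4 the estimated result in this assay is 33%, with a range from 18% to 48%.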

Compound 4, a percentage reported as inhibition, in the whole organism at one dose (the size of the read-out at that dose, not a potency): 44%
For compound 4 the middle estimate is 11 percentage points below the measured one; measured number inside the range.
By their numbers in this assay, from the lowest: compound 3; then compounds 2, 1 and 4 (each within the scatter of the next).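

In this assay, the place on the carbonyl carbon takes a ring amine as readily as an open-chain one: the step of a number 4 percentage points higher from compound 1 to compound 4 (within the scatter) and the step of a number 7 percentage points higher from compound 2 to compound 4 (within the scatter) both leave piperazin-1-yl level with diethylamino and isopropylamino, even though it brings a ring and a hydrogen-bond donor. Among these four compounds benzylamino alone stands apart, as the step of a number 20 percentage points higher from compound 3 to compound 4 (beyond the scatter) shows, and this gap is the largest seen so far in the set. Nothing measured here explains why the numbers fall this way.

Still open, as far as these compounds go, is whether the second ring nitrogen of piperazin-1-yl matters at all, which morpholin-4-yl or a piperidin-1-yl ring in the same place could test. From the compounds shown here alone, with only one dose, it also remains open how these compounds would compare at other doses.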